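The source may hold more compounds than are shown below. What is called first, only, known or untested is meant among the compounds shown, and "the series" means these compounds.

Measured in a physicochemical assay for lipophilicity, read by HPLC, at pH 7.5; a lower number here means a more polar compound, a higher number a more lipophilic compound:
- compound 1 `CC[C@@H](Nc1c(C#N)c(-c2ccc(-c3ccncc3C)cc2)nc2cnccc12)C(N)=O` gives 2
- compound 2 `CC[C@@H](Nc1c(C#N)c(-c2ccc(-c3ccc(F)cc3)cc2)nc2cnccc12)C(N)=O` gives 2.7
- compound 3 `CC[C@@H](Nc1c(C#N)c(-c2ccc(-c3ccccc3C(F)(F)F)cc2)nc2cnccc12)C(N)=O` gives 3.1

Compound 3 stands highest of the three, with compound 2 the nearest (2.7) and compound 1 the furthest (2). Compound 4 `CC[C@@H](Nc1c(C#N)c(-c2ccc(-c3ccccc3OC)cc2)nc2cnccc12)C(N)=O` has methoxy in place of trifluoromethyl on an aromatic carbon, ortho to a large group (methoxy in place of trifluoromethyl on an aromatic carbon). Its 2-methoxyphenyl thus replaces the 2-(trifluoromethyl)phenyl of compound 3. Within the data shown here, no measured pair makes this exact exchange. Two measured steps lead to the 2-(trifluoromethyl)phenyl group, one modest (a number 0.40 log units higher from compound 2 to compound 3 (beyond the scatter)) and one large (a number 1.10 log units higher from compound 1 to compound 3 (beyond the scatter)). The group of compound 2, a 4-fluorophenyl, has a ring of carbon only, as does 2-methoxyphenyl, so the modest step from compound 2 (a number 0.40 log units higher from compound 2 to compound 3 (beyond the scatter)) is taken as the closer guide. The expected change in this assay is modest and downward (a number 0.40 log units lower from compound 3 to compound 4 (beyond the scatter)). The estimate for compound 4 is 2.7 (expected range 2.3 to 3).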

Compound 4, distribution coefficient: 2.7
Estimate against measurement, compound 4: no gap at the digits printed; the range from low to high includes it.
By their numbers in this assay, from the lowest: compound 1; then compounds 2 and 4 (each within the scatter of the next); then compound 3.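

In this assay, among these compounds, methoxy in place of trifluoromethyl on an aromatic carbon, ortho to a large group, gives a number 0.40 log units lower from compound 3 to compound 4 (beyond the scatter) as the first direct reading of this exchange. The 2-methoxyphenyl and 4-fluorophenyl groups cannot be told apart in this assay, with no change at the digits printed from compound 2 to compound 4 (within the scatter) as their step, whereas 2-methoxyphenyl in place of 3-methylpyridin-4-yl gives a number 0.70 log units higher from compound 1 to compound 4 (beyond the scatter) and so matches the step of a number 0.70 log units higher from compound 1 to compound 2 (beyond the scatter) in size. Nothing given here accounts for these differences.

All three groups compared with trifluoromethyl and with each other at this place are aromatic rings, apart from the two small substituents exchanged on one of them. On these data alone, how an amine, a carboxylic acid or a longer chain in place of methoxy would read in this assay remains open.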